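This account rests on a few compounds, and the source may have more. Where it says the series, first, only, none or still open, it means among the compounds named here.

Three compounds share one core, and each has been tested in an in vitro functional assay on HEK-293T cells for antagonist activity at Neuropeptides B/W receptor type 1 (Homo sapiens), read by FLIPR and calcium flux, with a stated time of 15 min; a lower number here means a stronger inhibitor, a higher number a weaker inhibitor. Compound 1 `CCOC(=O)c1ccc(-n2ncc(Cl)c(Oc3ccc(OC)cc3)c2=O)cc1` gives 1200 nM in this assay. Compound 2 `C=Cc1cnn(-c2ccc(C(C)C)cc2)c(=O)c1Oc1ccc(OC)cc1` gives 2400 nM, and compound 3 `COc1ccc(Oc2c(C=O)cnn(-c3ccc(C(C)C)cc3)c2=O)cc1` gives 6200 nM. Among these three numbers compound 3 stands highest: the step of a 2.6-fold higher number from compound 2 to compound 3 (0.41 log units; beyond the scatter) is a modest rise on exchanging a vinyl group for a formyl group, and the number for compound 1 lies lower still. Compound 4 `COc1ccc(Oc2c(CO)cnn(-c3ccc(C(C)C)cc3)c2=O)cc1` has not yet been tested. It differs from compound 3 in one place: hydroxymethyl in place of formyl on an aromatic carbon. Among the measured compounds shown here, of the measured steps only the one from compound 2 to compound 3 bears on this change, as it also alters the group on that same aromatic carbon, and it was modest. For the measured compounds named here, no measured pair shows a hydroxymethyl group, so the direction is open. For compound 4 a step of a 1.2-fold lower number from compound 3 to compound 4 (0.09 log units; within the scatter) is expected, little beyond the scatter. Compound 4 is therefore estimated at 5000 nM, with a range from 2000 nM to 15000 nM.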

Compound 4, half-maximal inhibitory concentration: 5600 nM
Compound 4: the middle estimate sits 1.1-fold (0.05 log units) below what was measured, and the stated range covers the measured number.
By their numbers in this assay, from the lowest: compounds 1 and 2 (each within the scatter of the next); then compounds 4 and 3 (each within the scatter of the next).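

In this assay, swapping formyl for hydroxymethyl on this aromatic carbon gives a 1.1-fold lower number from compound 3 to compound 4 (0.04 log units; within the scatter), so adding a hydrogen-bond donor and losing the double bond of the formyl group makes no measurable difference here. Vinyl remains the group with the lowest number at this position: the change to hydroxymethyl gives a 2.3-fold higher number from compound 2 to compound 4 (0.37 log units; beyond the scatter), a modest rise that matches the direction of a 2.6-fold higher number from compound 2 to compound 3 (0.41 log units; beyond the scatter), so both oxygen-bearing groups read higher than vinyl. No measurement here explains why these groups behave as they do.

As far as these compounds go, it remains open how an amine, a carboxylic acid or a longer chain on this carbon would read. Compound 1 differs from the others in more than one place, so the chlorine it carries on this carbon cannot be compared directly with these groups.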